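Swapping the Aryl Group on the Carbonyl Carbon

The compounds below may be only part of what the source reports. "The series", "measured", "known", "first", "only" and "open" are said of these compounds alone.

Compound 1, `CC(=O)OCC(=O)N(/N=N/c1ccc([N+](=O)[O-])cc1Br)c1ccc([N+](=O)[O-])cc1Br`, gives 490 nM in a functional assay on HeLa cells (Homo sapiens) for cytotoxicity, read by MTT assay, with a stated time of 72 h; a lower number here means a stronger inhibitor, a higher number a weaker inhibitor.
Compound 2, `O=C(c1ccccc1F)N(/N=N/c1ccc([N+](=O)[O-])cc1Cl)c1ccc([N+](=O)[O-])cc1Cl`, gives 2350 nM in this assay.
Compound 3, `O=C(c1ccccc1C(F)(F)F)N(/N=N/c1ccc([N+](=O)[O-])cc1Cl)c1ccc([N+](=O)[O-])cc1Cl`, gives 10600 nM in this assay.

Among these three, compound 3 stands at the highest number, so it is the weakest inhibitor of the set; compound 2 is nearest to it and compound 1 furthest away, both with lower numbers and both separated from compound 3 by more than the usual scatter.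

Compound 4, `O=C(c1cccc(F)c1)N(/N=N/c1ccc([N+](=O)[O-])cc1Cl)c1ccc([N+](=O)[O-])cc1Cl`, is not yet measured. It differs from compound 3 in one place: 3-fluorophenyl in place of 2-(trifluoromethyl)phenyl on a carbonyl carbon. Among the measured compounds shown here, the one measured step that bears on this is a 4.5-fold higher number from compound 2 to compound 3 (0.65 log units; beyond the scatter), where putting trifluoromethyl in place of fluoro on an aromatic carbon made the inhibitor weaker. Compound 4 reverses that exchange, bringing back a single fluorine, though as 3-fluorophenyl rather than the group in compound 2. A step back down toward the number of compound 2 is therefore expected, about a 4.2-fold lower number from compound 3 to compound 4 (0.63 log units; beyond the scatter). Compound 4 is estimated at 2500 nM in this assay, with a likely range from 800 nM to 8000 nM.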

Compound 4, half-maximal inhibitory concentration: 2500 nM
Compound 4: middle estimate and measured number agree at the digits printed; the measured number falls inside the stated range.
By their numbers in this assay, from the lowest: compound 1; then compounds 2 and 4 (each within the scatter of the next); then compound 3.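

In this assay the step of a 1.1-fold higher number from compound 2 to compound 4 (0.03 log units; within the scatter) gives the first view of the fluorine's placement: 3-fluorophenyl and 2-fluorophenyl on the carbonyl carbon cannot be told apart here. The step of a 4.2-fold lower number from compound 3 to compound 4 (0.63 log units; beyond the scatter) then shows that both fluorophenyl compounds stand clear of the 2-(trifluoromethyl)phenyl compound, so among these three groups only that one gives a weaker inhibitor. No measurement shown here accounts for this difference.

Still open, from the compounds shown here alone, is how an unsubstituted phenyl, or a phenyl carrying an amine or a carboxylic acid, would compare on this carbonyl carbon. Also open, going by these compounds, is whether trifluoromethyl would give a similar number elsewhere on the ring, as compound 3 alone carries it.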